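Compound 3 to compound 4: a new group on nitrogen

The source may hold more compounds than are shown below. What is called first, only, known or untested is meant among the compounds shown, and "the series" means these compounds.

In a functional assay on HepG2 cells (Homo sapiens) for antiproliferative activity, read by MTT assay, with a stated time of 48 h (a higher number here means a weaker inhibitor, a lower number a stronger inhibitor), compound 1 (`Cc1ccc(-c2ccc3c(c2)C(=O)C(=O)N3)cc1`) gives 6000 nM and compound 2 (`O=C1Nc2ccc(-c3ccc(C(F)(F)F)cc3)cc2C1=O`) gives 5430 nM. Compound 3 (`COc1ccc(-c2ccc3c(c2)C(=O)C(=O)N3c2ccc(OC)cc2)cc1`) gives > 10000 nM, which is a limit and not a number; it is the limit of > 10000 nM in this assay, at which 1 of the 3 values shown sits. The change to compound 4 (`COc1ccc(-c2ccc3c(c2)C(=O)C(=O)N3Cc2ccccc2Cl)cc1`) is 2-chlorobenzyl in place of 4-methoxyphenyl on an amide-type nitrogen in a ring. Going by the values given here, the only measured step, a 1.1-fold lower number from compound 1 to compound 2 (0.04 log units; within the scatter), lies elsewhere on the shared core, so no measured step bears directly on this nitrogen. The expectation therefore leans on compound 1 at 6000 nM. A modest at least 1.4-fold lower number from compound 3 to compound 4 (0.15 log units; that floor lies within the scatter) is expected, towards a lower number. Compound 4 is estimated at 7000 nM, with a range of 2000 nM to 20000 nM.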

Compound 4, half-maximal inhibitory concentration: 600 nM
The estimate for compound 4 lay 12-fold (1.07 log units) above the measured number; measured number below the stated range.
By their numbers in this assay, from the lowest: compound 4; then compounds 2 and 1 (each within the scatter of the next). At a limit, above all of these: compound 3.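

The amide-type nitrogen of the shared core proves sensitive in this assay: an at least 16-fold lower number from compound 3 to compound 4 (1.22 log units; beyond the scatter). Going by these compounds alone, the only earlier step, a 1.1-fold lower number from compound 1 to compound 2 (0.04 log units; within the scatter), lay elsewhere on the core and gave no reading of this position. The number for compound 3 is a limit, so this step gives only a floor: the limit of > 10000 nM in this assay, at which 1 of the 4 values shown sits.

The compounds shown do not separate the chlorine from the benzyl link as the part of 2-chlorobenzyl that carries the step. As far as these compounds go, how an amine or a longer chain on this nitrogen would read also remains open.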